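Hydroxy-to-fluoro exchange repeated on a second core

The source may report more compounds than this note shows. Statements on the series, on what has been measured and on what is new or still open speak of the compounds shown alone.

Measured in an assay on blood for inhibition of Polyunsaturated fatty acid 5-lipoxygenase (Homo sapiens), tested at 10 uM; a higher number here means a stronger effect of the compound at the concentration tested, a lower number a weaker effect:
compound 1 `O=C1OC(c2cc(OCc3ccccc3)cc(OCc3ccccc3)c2)C(c2ccc(F)cc2)=C1O` gives 0%
compound 2 `O=C1OC(c2cc(OCc3ccccc3)cc(OCc3ccccc3)c2)C(c2ccc(O)cc2)=C1O` gives 32%
compound 3 `O=C1OC(c2ccc(O)cc2)C(c2ccc(O)cc2)=C1O` gives 0%

Among the compounds with values here, the one counted change in the set is fluoro in place of hydroxy on an aromatic carbon, which in this assay gave a number 32 percentage points lower from compound 2 to compound 1 (beyond the scatter). Compound 3 carries a different core from compound 2; the difference between the two cores is not broken down here, and the two values merely show that compound 3 sits well under compound 2. Compound 3 is level with compound 1 within the scatter.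

Compound 4 `O=C1OC(c2ccc(O)cc2)C(c2ccc(F)cc2)=C1O` is compound 3 after the same change, (fluoro in place of hydroxy on an aromatic carbon), made at the same place. The earlier step lowered the read-out, but compound 3 already gives 0%, so no room remains for a drop of that size. The step from compound 3 to compound 4 is therefore expected to be small, no change at the digits printed from compound 3 to compound 4 (within the scatter), set beside the earlier a number 32 percentage points lower from compound 2 to compound 1 (beyond the scatter). For compound 4 in this assay the estimate is 0%, between 0% and 10%.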

Compound 4, a percentage reported as activity, at one concentration (the size of the read-out at that concentration, not a potency): 0%
Estimate against measurement, compound 4: no gap at the digits printed, within the range that was stated.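

In this assay, the exchange of 4-hydroxyphenyl for 4-fluorophenyl does not repeat its size on the second core, where the step reads no change at the digits printed from compound 3 to compound 4 (within the scatter). The two steps differ: the same change on two cores in this assay, a number 32 percentage points lower (beyond the scatter) from compound 2 to compound 1 and no change at the digits printed (within the scatter) from compound 3 to compound 4, 32 percentage points apart, beyond the scatter of two such steps. This does not show that the hydroxy group is dispensable on the second core or that the two cores respond differently to it: compound 3 already gives 0%, so a lowering could not be read there, and only the core of compound 2, with a measurable starting value, gives a usable reading of this exchange.

Open, on these data alone, is whether an amine, a methoxy group or a carboxylic acid at this place on the core of compound 2 would hold the read-out near that of compound 2 or take it to the level of compound 1. Also open, as far as these compounds go, is which part of the difference between the two cores sets compound 2 above compound 3, as these two compounds differ in more than one place.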